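This account rests on a few compounds, and the source may have more. Where it says the series, first, only, none or still open, it means among the compounds named here.

Measured so far in an assay on isolated protein for inhibition of acyl-CoA desaturase 1 (Rattus norvegicus); a higher number here means a weaker inhibitor, a lower number a stronger inhibitor:
- compound 1, `CS(=O)(=O)c1ccc2nc(-c3ccc(-c4ccc(Cl)cc4)cc3)[nH]c2c1`: the value for compound 1 is a limit of this assay, > 20000 nM
- compound 2, `CS(=O)(=O)c1ccc2nc(-c3ccc(-c4cccc(F)c4)cc3)[nH]c2c1`: compound 2 gives 21 nM
- compound 3, `CS(=O)(=O)c1ccc2nc(-c3ccc(-c4ccccn4)cc3)[nH]c2c1`: compound 3 gives 1710 nM

Compound 3 stands highest of the two numbers in this assay; its nearest neighbour is compound 2, with a step of an 81-fold higher number from compound 2 to compound 3 (1.91 log units; beyond the scatter). The third value, that of compound 1, is a limit only, as noted under (the limit of > 20000 nM in this assay, at which 1 of the 3 values shown sits).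

Compound 4, `Cc1ccsc1-c1ccc(-c2nc3ccc(S(C)(=O)=O)cc3[nH]2)cc1`, has not been measured. The change from compound 3 is 3-methylthiophen-2-yl in place of pyridin-2-yl on an aromatic carbon.

Among the measured compounds shown here, three measured steps concern exchanges of the ring at this same place: an at least 950-fold lower number from compound 1 to compound 2 (2.97 log units; beyond the scatter), an at least 11-fold lower number from compound 1 to compound 3 (1.06 log units; beyond the scatter) and an 81-fold higher number from compound 2 to compound 3 (1.91 log units; beyond the scatter). All three are large, and they do not point one way: the two rings without a ring nitrogen sit at opposite ends, compound 2 at the low end and compound 1 at the limit. The 3-methylthiophen-2-yl ring of compound 4 resembles neither closely, so a large step in either direction is possible and the expected number is uncertain.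

On balance compound 4 is expected to give a lower number than compound 3, an estimated step of a 6.8-fold lower number from compound 3 to compound 4 (0.84 log units; beyond the scatter). The estimate for compound 4 in this assay is 250 nM, within a wide range from 20 nM to 3000 nM.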

Compound 4, half-maximal inhibitory concentration: 472 nM
Compound 4: the middle estimate sits 1.9-fold (0.28 log units) below what was measured, and the stated range covers the measured number.
By their numbers in this assay, from the lowest: compound 2; then compound 4; then compound 3. At a limit, above all of these: compound 1.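

In this assay, among the compounds shown here, the five-membered 3-methylthiophen-2-yl ring fits into a series so far made up of six-membered rings, with a 3.6-fold lower number from compound 3 to compound 4 (0.56 log units; beyond the scatter), and no ring nitrogen is needed for a number below that of the pyridin-2-yl ring. The absence of a ring nitrogen does not sort the series, however: a 22-fold higher number from compound 2 to compound 4 (1.35 log units; beyond the scatter) shows that two such rings still lie far apart, and compound 2 keeps the lowest number of the compounds shown. The third step, an at least 42-fold lower number from compound 1 to compound 4 (1.62 log units; beyond the scatter), is only a bound, with compound 1 standing at a limit and not at a number: the limit of > 20000 nM in this assay, at which 1 of the 4 values shown sits.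

The compounds shown leave open whether the low number of compound 2 depends on the fluorine itself or on where the substituent sits on the ring, a question that 3-chlorophenyl and 4-fluorophenyl rings would separate. They also leave open what the methyl group contributes in compound 4, which an unsubstituted thiophen-2-yl ring would address, and how a carboxylic acid or an amine on this ring would read in this assay.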